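The compounds below may be only part of what the source reports. "The series", "measured", "known", "first", "only" and "open" are said of these compounds alone.

Working notes on the series. Compound 1 `O=C1Nc2cc(Cl)ccc2/C1=C\c1cccc(OCc2cn(Cc3ccccc3)nn2)c1` and compound 2 `O=C1Nc2ccc(Br)cc2/C1=C/c1cccc(OCc2cn(Cc3ccccc3)nn2)c1` share their core with compound 3 `O=C1Nc2ccc(F)cc2/C1=C\c1cccc(OCc2cn(Cc3ccccc3)nn2)c1` and with compound 4 `CC(=O)c1ccc2c(c1)/C(=C\c1cccc(OCc3cn(Cc4ccccc4)nn3)c1)C(=O)N2`. In a functional assay on DU-145 cells (Homo sapiens) for inhibition, read by MTT assay, with a stated time of 48 h (a lower number here means a stronger inhibitor, a higher number a weaker inhibitor), compound 1 gives 20100 nM. In this assay, within the data shown here, compound 2 gives 35100 nM; no step between these two has been worked out, and the pair shows only two weak results of similar size. Compound 3 has no result in this assay: for compound 3 the entry reads "not determined" (no result reported), so it cannot be placed on the scale that compound 1 and compound 2 define, beyond belonging to the same weak series. The change from compound 3 to compound 4 is acetyl in place of fluoro on an aromatic carbon. Among the measured compounds shown here, no step between measured compounds covers this change, so the size of the move in this assay is open; no shift beyond the scatter is assumed in either direction, and compound 4 is expected to sit near where compound 1 and compound 2 sit. Compound 4 is therefore estimated at 25000 nM, within 8000 nM to 80000 nM.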

Compound 4, half-maximal inhibitory concentration: > 50000 nM
Compound 4 ended at the assay's limit; the forecaster's own chance of this, stated with the estimate: 20%; at least 2.0-fold (0.30 log units) between middle value and limit.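

No new step can be read between compound 3 and compound 4. In this assay compound 4 gives > 50000 nM, which is a limit and not a number: the limit of > 50000 nM in this assay, at which 1 of the 4 values shown sits. The compounds shown leave open how far acetyl in place of fluoro moves the value in this assay.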